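Imidazolyl to Methoxy: Estimating Compound 4

This account rests on a few compounds, and the source may have more. Where it says the series, first, only, none or still open, it means among the compounds named here.

Among the measured compounds shown here, compound 3 `CS(=O)(=O)c1cc(C(=O)N=C(N)N)ccc1-n1ccnc1` gives 150 nM in a functional assay for inhibition of sodium/hydrogen exchanger (Oryctolagus cuniculus) (a higher number here means a weaker inhibitor, a lower number a stronger inhibitor), the highest of the three numbers measured so far. Compound 4 `COc1ccc(C(=O)N=C(N)N)cc1S(C)(=O)=O` differs from compound 3 by methoxy in place of 1H-imidazol-1-yl on an aromatic carbon. For the measured compounds named here, the only step measured in one place, a 2.5-fold higher number from compound 1 to compound 2 (0.40 log units; beyond the scatter), concerns a different position and does not bear directly on this change. Still, compound 1 `COc1cc(C)c(C(=O)N=C(N)N)cc1S(C)(=O)=O` with 16 nM and compound 2 `COc1cc(Cl)c(C(=O)N=C(N)N)cc1S(C)(=O)=O` with 40 nM, which both carry the methoxy group together with a further substituent, lie well under compound 3 in this assay. A lower number is therefore expected for compound 4, in the step of a 3.0-fold lower number from compound 3 to compound 4 (0.48 log units; beyond the scatter). Compound 4 is estimated at 50 nM, within a range from 15 nM to 160 nM.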

Compound 4, half-maximal inhibitory concentration: 270 nM
The estimate for compound 4 lay 5.4-fold (0.73 log units) below the measured number; measured number above the stated range.
By their numbers in this assay, from the lowest: compound 1; then compound 2; then compounds 3 and 4 (each within the scatter of the next).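

In this assay methoxy in place of 1H-imidazol-1-yl, ortho to a methylsulfonyl group, gives a 1.8-fold higher number from compound 3 to compound 4 (0.26 log units; within the scatter) and thus no clear separation between the two groups. Hydrogen in place of chloro gives a 6.8-fold higher number from compound 2 to compound 4 (0.83 log units; beyond the scatter) while hydrogen in place of methyl gives a 17-fold higher number from compound 1 to compound 4 (1.23 log units; beyond the scatter) and the low numbers of compound 1 and compound 2 thus go with their further substituent rather than with methoxy alone. Nothing available explains these steps.

Going by these compounds, whether an amine or ethoxy at this place would separate from methoxy remains open. So does how 1H-imidazol-1-yl would compare with methoxy in a compound that also carries methyl.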